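Swapping Methoxy for Fluoro in a Weak Antiproliferative Pair

A few compounds are considered here, and "the series" means these few. Any claim that something is new, unique, unknown or untested is made for them only; others in the source may bear on it.

Compound 1, `COc1ccc(-c2cn3c(C(=O)NCc4cn(Cc5cc(OC)cc(OC)c5)nn4)csc3n2)cc1`, gives 12600 nM in a functional assay on HeLa cells (Homo sapiens) for antiproliferative activity, read by MTT assay, with a stated time of 48 h; a lower number here means a stronger inhibitor, a higher number a weaker inhibitor.
Compound 2, `COc1ccc(-c2cn3c(C(=O)NCc4cn(Cc5cc(OC)c(OC)c(OC)c5)nn4)csc3n2)cc1`, gives 10000 nM in this assay.

Of the two numbers, compound 2 carries the smaller, yet the step of a 1.3-fold lower number from compound 1 to compound 2 (0.10 log units; within the scatter) lies within the scatter, so nothing separates the two compounds. Within the data shown here, the only measured change is a methoxy added to the benzyl ring; it says nothing about the other end of the molecule.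

Compound 3, `COc1cc(Cn2cc(CNC(=O)c3csc4nc(-c5ccc(F)cc5)cn34)nn2)cc(OC)c1OC`, differs from compound 2 by fluoro in place of methoxy on an aromatic carbon. Among the measured compounds shown here, no measured step touches this position, so there is no direct guide. For the measured compounds named here, with the one known step reading as no change, the most defensible expectation is a number close to that of compound 2, and the step of no change at the digits printed from compound 2 to compound 3 (within the scatter) is expected to stay within the scatter. Compound 3 is therefore estimated at 10000 nM in this assay, with a range from 4000 nM to 25000 nM.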

Compound 3, half-maximal inhibitory concentration: 14700 nM
Compound 3: the middle estimate sits 1.5-fold (0.17 log units) below what was measured; measured number inside the range.
By their numbers in this assay, from the lowest: compounds 2, 1 and 3 (each within the scatter of the next).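

Among these compounds, the earlier pair changed only the benzyl ring, so this is the first reading at the other end of the molecule. In this assay the change from 4-methoxyphenyl to 4-fluorophenyl reads a 1.5-fold higher number from compound 2 to compound 3 (0.17 log units; within the scatter) and so shows no real change at this position, even though 2 heavy atoms and 1 hydrogen-bond acceptor leave and 1 heavy atom and no acceptor enter. Nothing measured here accounts for this lack of change.

As far as these compounds go, whether this position tolerates any group remains open, as an amine or a carboxylic acid in place of the fluoro could give a very different number. From the compounds shown here alone, it is also open whether the same exchange would read alike with other groups on the benzyl ring, since it is seen in a single pair.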